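A few compounds are considered here, and "the series" means these few. Any claim that something is new, unique, unknown or untested is made for them only; others in the source may bear on it.

Measured in a functional assay on MDA-MB-231 cells (Homo sapiens) for antiproliferative activity, read by MTT assay; a higher number here means a weaker inhibitor, a lower number a stronger inhibitor:
compound 1 `CC/C=C\C/C=C\C/C=C\CCCCCCCC1(O)CC(=O)c2c(O)cc(OCOC)cc2O1` gives 6790 nM
compound 2 `CCCCC/C=C\C/C=C\CCCCCCCC1(O)CC(=O)c2c(O)cc(OCOC)cc2O1` gives 16100 nM
compound 3 `CCCCC/C=C\C/C=C\CCCCCCCC1(O)CC(=O)c2c(O)c(C)c(O)c(C)c2O1` gives 42800 nM

Compound 4 `CC/C=C\C/C=C\C/C=C\CCCCCCCC1(O)CC(=O)c2c(O)c(C)c(O)c(C)c2O1` has not been measured yet. Compound 1 and compound 2 share one core, while compound 3 and compound 4 share another; the difference between the two cores is not broken down here. Within the first pair the change is but-1-en-1-yl in place of butyl on a saturated chain carbon bound to a double-bonded chain carbon, and it made a 2.4-fold lower number from compound 2 to compound 1 (0.37 log units; beyond the scatter). The same change at the same place leads from compound 3 to compound 4: but-1-en-1-yl in place of butyl on a saturated chain carbon bound to a double-bonded chain carbon. Compound 3 gives the highest number of the three measured compounds. Resting on that single earlier step, a similar step is expected, a 2.4-fold lower number from compound 3 to compound 4 (0.38 log units; beyond the scatter), though one example on a different core is a thin basis. Compound 4 is therefore estimated at 18000 nM, most likely between 8000 nM and 40000 nM.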

Compound 4, half-maximal inhibitory concentration: 42800 nM
Beside the measured number, compound 4's estimate is 2.4-fold (0.38 log units) below it, and the stated range ends below it.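

In this assay, putting but-1-en-1-yl in place of butyl on a saturated chain carbon bound to a double-bonded chain carbon gave no change at the digits printed from compound 3 to compound 4 (within the scatter). Set beside the same change on the other core, the two steps do not differ beyond the scatter: the same change on two cores in this assay, a 2.4-fold lower number (0.37 log units; beyond the scatter) from compound 2 to compound 1 and no change at the digits printed (within the scatter) from compound 3 to compound 4, 2.4-fold (0.37 log units) apart, within the scatter of two such steps. For the compounds shown here, the change therefore lowered the number clearly on only one core, yet this single pair on each core neither shows that its effect carries over nor shows that it fails to.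

The compounds shown leave open how the difference between the two cores acts on its own. They also leave open whether a shorter chain, or a chain ending in an amine or a carboxylic acid, would shift the number in this assay.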